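The source may report more compounds than this note shows. Statements on the series, on what has been measured and on what is new or still open speak of the compounds shown alone.

In a functional assay on NCI-H1975 cells (Homo sapiens) for antiproliferative activity, read by MTT assay, with a stated time of 72 h (on this read-out higher numbers stand for weaker inhibition and lower numbers for stronger inhibition), the measured members of the series read as follows:

compound 1 `COc1cc2ncnc(Nc3ccc(F)c(Cl)c3)c2cc1OCCCCC(=O)Nc1ccc(S(N)(=O)=O)cc1`: 35600 nM
compound 2 `C#Cc1cccc(Nc2ncnc3cc(OC)c(OCCCCC(=O)Nc4ccc(S(N)(=O)=O)cc4)cc23)c1`: 18800 nM
compound 3 `NS(=O)(=O)c1ccc(NC(=S)Nc2ccc3ncnc(Nc4ccc(F)c(Cl)c4)c3c2)cc1`: 15800 nM

Compound 1 and compound 2 share one core and differ in a single place: 3-ethynylphenyl in place of 3-chloro-4-fluorophenyl on a nitrogen on an aromatic ring. In this assay that change gives a 1.9-fold lower number from compound 1 to compound 2 (0.28 log units; within the scatter), so on this pair the exchange has not produced a difference that can be trusted.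

Compound 3 carries a different core; how the core of compound 3 differs from the core of compound 1 is not broken down here. What the two numbers show is that compound 3 in this assay gives 15800 nM against compound 1 at 35600 nM, a gap that lies beyond the scatter. Compound 3 and compound 2, by contrast, sit within the scatter of each other, so no order between them is claimed.

Compound 4 `C#Cc1cccc(Nc2ncnc3ccc(NC(=S)Nc4ccc(S(N)(=O)=O)cc4)cc23)c1` is not yet measured. It stands to compound 3 as compound 2 stands to compound 1: 3-ethynylphenyl in place of 3-chloro-4-fluorophenyl on a nitrogen on an aromatic ring. The place of the change is described in the same words for both pairs, so this is the same change on a second core.

The expectation for compound 4 rests on one precedent only, the step from compound 1 to compound 2 of a 1.9-fold lower number from compound 1 to compound 2 (0.28 log units; within the scatter), applied to compound 3 at 15800 nM. On that basis the estimated step is a 1.9-fold lower number from compound 3 to compound 4 (0.27 log units; within the scatter), a movement that is itself within the scatter. Compound 4 is therefore expected to give about 8500 nM in this assay, with a plausible range from 3500 nM to 22000 nM.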

Compound 4, half-maximal inhibitory concentration: 13400 nM
For compound 4 the middle estimate is 1.6-fold (0.20 log units) below the measured one; measured number inside the range.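

In this assay, the exchange of 3-chloro-4-fluorophenyl for 3-ethynylphenyl on the second core gives a 1.2-fold lower number from compound 3 to compound 4 (0.07 log units; within the scatter), so on this pair too the change produces no difference that can be trusted. Set beside the earlier pair, the exchange reads alike on both cores, with no sign that the core alters its outcome: the same change on two cores in this assay, a 1.9-fold lower number (0.28 log units; within the scatter) from compound 1 to compound 2 and a 1.2-fold lower number (0.07 log units; within the scatter) from compound 3 to compound 4, 1.6-fold (0.21 log units) apart, within the scatter of two such steps. This shows only that, across these two pairs, swapping one group for the other leaves the numbers within the scatter; it does not show a real effect of the change that carries from core to core, and two pairs cannot establish that the same would hold on any further core.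

The compounds shown leave open whether a different group on the same nitrogen, such as an unsubstituted phenyl or a 3-bromophenyl, would give a step beyond the scatter on either core. Also open, on these data alone, is whether a carboxylic acid in place of the sulfonamide, or a shorter or longer chain in the linker of compound 1 and compound 2, would move the numbers in this assay.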